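The compounds below may be only part of what the source reports. "The series", "measured", "known", "first", "only" and "open" are said of these compounds alone.

Measured compounds:
- compound 1, `O=C(O)c1cn(Cc2ccc(Br)cc2)c2ccccc2c1=O`: "not determined" (no result reported) in a functional assay, tested at 10 uM; on this read-out lower numbers stand for a weaker effect and higher numbers for a stronger effect at the one concentration tested
- compound 2, `O=C(O)c1cn(Cc2ccc(O)cc2)c2ccccc2c1=O`: 14.6%

Among the measured compounds shown here, compound 2 is the only member of the series with a number in this assay; compound 1 carries no result, so nothing can be said of a step between the two. On the numbers shown, compound 2 therefore stands alone, with a low read-out in this assay, and there is no measured step between compounds differing in one place to set a scale for what a single change does here.

Compound 3, `O=C(O)c1cn(Cc2ccc(O)c(O)c2)c2ccccc2c1=O`, is the next compound to be measured. It differs from compound 2 by hydroxy in place of hydrogen on an aromatic carbon. For the measured compounds named here, no measured step in this assay gives a precedent for a hydroxy entering in place of hydrogen in this position, so the expectation rests on compound 2 alone. The step is expected to be small, with no clear direction beyond the scatter: the estimated change is a number 2.4 percentage points higher from compound 2 to compound 3 (within the scatter). Compound 3 is estimated to give 17% in this assay, in a range from 5% to 35%.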

Compound 3, a percentage reported as activity, at one concentration (the size of the read-out at that concentration, not a potency): 44.9%
Compound 3: the middle estimate sits 27.9 percentage points below what was measured, and the stated range ends below it.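

Among the compounds shown here, the first readable step in this assay shows that this position is far from silent: hydroxy in place of hydrogen on an aromatic carbon, ortho to a hydroxy group and meta to a large group, gives a number 30.3 percentage points higher from compound 2 to compound 3 (beyond the scatter) and so lifts a low read-out to a clearly higher one. A single added hydroxy on this ring is therefore enough to change the read-out at the one concentration tested, and this one pair gives the series its first scale for a single change, though it establishes no general pattern. Nothing available bears on why the step has this size.

Still open, on these data alone, is whether another group in this same place, such as a methoxy group, an amine or a fluorine atom, would keep the higher read-out, or whether only hydroxy does so. Also open, as far as these compounds go, is whether the step depends on the hydroxy group already present in compound 2, since compound 1 gives "not determined" (no result reported) in this assay and so offers no comparison for the substituent at that other place.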